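This account rests on a few compounds, and the source may have more. Where it says the series, first, only, none or still open, it means among the compounds named here.

Series so far, read in a functional assay (aorta, strain Wistar) for inhibition, with Rattus norvegicus as the target (on this read-out higher numbers stand for weaker inhibition and lower numbers for stronger inhibition), and given as measured values:

- compound 1 `CCCCc1nc(Cl)c(COC(=O)CCCCO[N+](=O)[O-])n1Cc1ccc(-c2ccccc2-c2nn[nH]n2)cc1` gives 851 nM
- compound 2 `CCCCc1nc(Cl)c(COC(=O)c2cccc(CO[N+](=O)[O-])c2)n1Cc1ccc(-c2ccccc2-c2nn[nH]n2)cc1` gives 275 nM
- compound 3 `CCCCc1nc(Cl)c(COC(=O)c2c(C)ccc(CO[N+](=O)[O-])c2C)n1Cc1ccc(-c2ccccc2-c2nn[nH]n2)cc1` gives 32400 nM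

Compound 2 holds the lowest number of the three, and compound 3 the highest. The next compound to read is compound 4 `CCCCc1nc(Cl)c(COC(=O)c2cccc(CO[N+](=O)[O-])n2)n1Cc1ccc(-c2ccccc2-c2nn[nH]n2)cc1`, which has 6-((nitrooxy)methyl)pyridin-2-yl in place of 3-((nitrooxy)methyl)phenyl on a carbonyl carbon. Within the data shown here, the one measured step at this place (a 3.1-fold lower number from compound 1 to compound 2 (0.49 log units; beyond the scatter)) was modest. It replaced 4-(nitrooxy)butyl, a different kind of swap, so it bears only loosely on this one. Among the measured compounds shown here, no measured step replaces a carbon-only ring with a ring holding a hetero atom. A small change is therefore expected, with no firm direction and a slight lean towards a higher number, since compound 2 (275 nM) already sits lowest. The expected change is a 1.3-fold higher number from compound 2 to compound 4 (0.10 log units; within the scatter) in the estimate. The wide spread shown by compound 3 (32400 nM) argues for a broad expected range. For compound 4 the estimated value is 350 nM, with an expected range from 90 nM to 1400 nM.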

Compound 4, half-maximal inhibitory concentration: 12300 nM
The estimate for compound 4 lay 35-fold (1.55 log units) below the measured number, outside the stated range (above it).
By their numbers in this assay, from the lowest: compound 2; then compound 1; then compound 4; then compound 3.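

In this assay, among these compounds, the ring bearing the nitrooxymethyl group on the carbonyl carbon proves highly sensitive to a single atom: 6-((nitrooxy)methyl)pyridin-2-yl in place of 3-((nitrooxy)methyl)phenyl gives a 45-fold higher number from compound 2 to compound 4 (1.65 log units; beyond the scatter), although the heavy-atom count stays the same and only one ring carbon becomes nitrogen. The modest advantage of the phenyl group over 4-(nitrooxy)butyl therefore does not extend to both aromatic rings shown, as the pyridinyl group falls behind the open chain, with a 14-fold higher number from compound 1 to compound 4 (1.16 log units; beyond the scatter). Nothing measured here accounts for the size of this step.

From the compounds shown here alone, it remains open whether a hydroxymethyl group in place of the nitrooxymethyl group would show the same gap between the two rings. Also open, going by these compounds, is whether a thiophene ring at this place would read closer to the phenyl or the pyridinyl compound.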